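This account rests on a few compounds, and the source may have more. Where it says the series, first, only, none or still open, it means among the compounds named here.

Compound 1 `COc1cc2c(cc1OC)C(CC(N)=O)CC2`: in a functional assay on the whole organism (strain Wistar) for inhibition, with Rattus norvegicus as the target, read by paw edema, with stated times of 60 min and 1 h, at a dose of 100 mg/kg by the oral route (on this read-out lower numbers stand for less inhibition and higher numbers for more inhibition at the one dose given (going by the name of the read-out)), compound 1 gives 18.8%.
Compound 2 `CCCNC(=O)CC1CCc2cc(OC)c(OC)cc21`: in this assay compound 2 gives 18.8%.
Compound 3 `COc1cc2c(cc1OC)C(CC(=O)N1CCCC1)CC2`: in this assay compound 3 gives 4.69%.

Among these three, compound 3 stands lowest, and its steps to both compound 1 and compound 2 lie beyond the scatter. The step of no change at the digits printed from compound 1 to compound 2 (within the scatter) shows that propyl in place of hydrogen on the amide-type nitrogen left the number where it was, whereas a number 14.1 percentage points lower from compound 1 to compound 3 (beyond the scatter) and a number 14.1 percentage points lower from compound 2 to compound 3 (beyond the scatter) both took the number down by the same modest amount, each putting pyrrolidin-1-yl in place of an open amino or propylamino group on the carbonyl carbon.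

Compound 4 `COc1cc2c(cc1OC)C(CC(=O)N1CCCCC1)CC2` differs from compound 3 in one place: piperidin-1-yl in place of pyrrolidin-1-yl on a carbonyl carbon. For the measured compounds named here, no measured step exchanges one ring amine for another; the two steps that reach compound 3 concern the move from an open nitrogen group to pyrrolidin-1-yl, not the size of that ring, so they bear on the present change only loosely. Compound 3 already stands low, and nothing measured gives a direction. The step of a number 2.3 percentage points higher from compound 3 to compound 4 (within the scatter) is expected to stay within the scatter. Compound 4 is therefore estimated at 7%, with a range from 0% to 20%.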

Compound 4, a percentage reported as inhibition, in the whole organism at one dose (the size of the read-out at that dose, not a potency): 18.8%
The estimate for compound 4 lay 11.8 percentage points below the measured number; the measured number falls inside the stated range.
By their numbers in this assay, from the lowest: compound 3; then compounds 1, 2 and 4 (each within the scatter of the next).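

In this assay, the carbonyl carbon proved sensitive to a change of a single ring member, since piperidin-1-yl in place of pyrrolidin-1-yl gave a number 14.1 percentage points higher from compound 3 to compound 4 (beyond the scatter). The earlier drop therefore goes with pyrrolidin-1-yl alone and not with ring amines on this carbon in general, as the open groups also match piperidin-1-yl, with no change at the digits printed from compound 1 to compound 4 (within the scatter) and no change at the digits printed from compound 2 to compound 4 (within the scatter). Nothing available explains why the five-membered ring stands apart from the six-membered one.

The compounds shown leave open whether azepan-1-yl or morpholin-4-yl on the same carbonyl carbon would stay with compound 4 or fall towards compound 3. They also leave open whether a butyl chain or a benzyl group on the amide nitrogen would shift the number at all.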